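Swapping the chain for a phenyl ring at the ring carbon

The source may report more compounds than this note shows. Statements on the series, on what has been measured and on what is new or still open speak of the compounds shown alone.

Measured so far:
- compound 1, `CCCC1Oc2c(C)c(C)c(O)c(C)c2S1`: 25 nM
- compound 2, `CCCCCCCC1Oc2c(C)c(C)c(O)c(C)c2S1`: 220 nM

In a functional assay on ileum (Cavia porcellus) for inhibition of Polyunsaturated fatty acid 5-lipoxygenase (Homo sapiens) (on this read-out higher numbers stand for weaker inhibition and lower numbers for stronger inhibition), compound 1 gives 25 nM, the lowest of the two numbers shown. Compound 2, carrying a longer chain on the shared core, gives 220 nM; the step of an 8.8-fold higher number from compound 1 to compound 2 (0.94 log units; beyond the scatter) shows that lengthening the chain at this position brought a clearly weaker result.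

Compound 3, `Cc1c(C)c2c(c(C)c1O)SC(c1ccccc1)O2`, changes the same position in a different way: phenyl in place of propyl on a saturated ring carbon. Nothing measured bears directly on a flat ring at this place. Within the data shown here, the one measured step, from compound 1 to compound 2, shows that adding bulk to the substituent on this saturated ring carbon cost potency, so a move from propyl to a larger phenyl is expected to go the same way, though the group is of a different kind and the step is uncertain. A modest weakening is expected, a 2.4-fold higher number from compound 1 to compound 3 (0.38 log units; beyond the scatter), rather than an improvement.

Compound 3 is therefore estimated at 60 nM in this assay, with a likely range from 15 nM to 250 nM.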

Compound 3, half-maximal inhibitory concentration: 71 nM
The estimate for compound 3 lay 1.2-fold (0.07 log units) below the measured number, within the range that was stated.
By their numbers in this assay, from the lowest: compound 1; then compound 3; then compound 2.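

In this assay, the change a 2.8-fold higher number from compound 1 to compound 3 (0.45 log units; beyond the scatter) shows that this saturated ring carbon tolerates a six-membered aromatic ring of carbon only, at a modest cost compared with propyl. Until now, only chains had been seen at this place, so the earlier pair could not show whether any larger group would lose as much as the longer chain did. The printed values now give a first answer: compound 2 gives 220 nM and compound 3 gives 71 nM in this assay while propyl, in compound 1, still has the lowest number of the three, and no evidence at hand says what lies behind this order.

On these data alone, whether a shorter chain such as ethyl would give a lower number than propyl remains open, as does the effect of a saturated ring such as cyclohexyl, which would show whether a ring at this carbon behaves like phenyl or like a chain. Also open, as far as these compounds go, is whether a phenyl ring bearing a methoxy group, or a pyridine ring in its place, would recover the modest loss seen with phenyl.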